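Methoxy addition on the aromatic ring in a dimethoxyphenyl series

The compounds below may be only part of what the source reports. "The series", "measured", "known", "first", "only" and "open" are said of these compounds alone.

Measured so far:
- compound 1 `COc1ccc(OC)c([C@H]2CC(C)(O)[C@@H]3CC[C@@H](C)C[C@H]3O2)c1`: 512000 nM
- compound 2 `COc1cc(OC)c([C@H]2CC(C)(O)[C@@H]3CC[C@@H](C)C[C@H]3O2)cc1OC`: > 857000 nM
- compound 3 `COc1ccc([C@H]2CC(C)(F)[C@@H]3CC[C@@H](C)C[C@H]3O2)cc1`: 171000 nM

In an ADME assay on MDCK cells (Canis lupus familiaris) for cytotoxicity, read by MTT assay, with a stated time of 48 h (on this read-out lower numbers stand for higher toxicity in this test and higher numbers for lower toxicity in this test), compound 1 gives 512000 nM. Compound 2 reaches only the limit of this assay, > 857000 nM, which is a limit and not a number. Compound 3 gives 171000 nM in this assay, the lowest of the two numbers shown, with compound 1 the nearest at a higher number, a gap beyond the scatter.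

The step from compound 1 to compound 2 is methoxy in place of hydrogen on an aromatic carbon, and in this assay it gave an at least 1.6-fold higher number from compound 1 to compound 2 (0.22 log units; that floor lies within the scatter). The floor of that step lies within the scatter, so it reads as little or no change, noting that compound 2 sits at a limit (the limit of > 857000 nM in this assay, at which 1 of the 3 values shown sits).

Compound 4 `COc1ccc([C@H]2CC(C)(F)[C@@H]3CC[C@@H](C)C[C@H]3O2)cc1OC` is not yet measured. It differs from compound 3 by methoxy in place of hydrogen on an aromatic carbon. This is the same kind of change as that from compound 1 to compound 2, but not the same: in the earlier pair the entering methoxy is also meta to a methoxy group and para to a large group, whereas here it is meta to a large group. How the core of compound 3 differs from that of compound 1 is not broken down here.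

For compound 4 in this assay, a step of a 1.5-fold higher number from compound 3 to compound 4 (0.16 log units; within the scatter) is expected, resting on the small and uncertain step from compound 1 to compound 2 of an at least 1.6-fold higher number from compound 1 to compound 2 (0.22 log units; that floor lies within the scatter). Compound 4 is therefore estimated at 250000 nM, with a range from 120000 nM to 600000 nM.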

Compound 4, half-maximal cytotoxic concentration: 20000 nM
For compound 4 the middle estimate is 13-fold (1.10 log units) above the measured one; measured number outside the range, below it.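

In this assay, methoxy in place of hydrogen on an aromatic carbon gave an 8.6-fold lower number from compound 3 to compound 4 (0.93 log units; beyond the scatter), which on this read-out means higher toxicity in this test, and the change did not carry over from one core to the other as a step of the same size: the same change on two cores in this assay, an at least 1.6-fold higher number (0.22 log units; that floor lies within the scatter) from compound 1 to compound 2 and an 8.6-fold lower number (0.93 log units; beyond the scatter) from compound 3 to compound 4, at least 14-fold (1.15 log units) apart, beyond the scatter of two such steps

For compound 2 the value > 857000 nM is a limit of the assay and not a number, so the earlier step is known only as a floor: the limit of > 857000 nM in this assay, at which 1 of the 4 values shown sits.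

In compound 4 the entering methoxy stands ortho to a methoxy group and meta to a large group, a place it does not hold in compound 2, and the two pairs also differ in their cores, so these results do not show which of the two differences separates the steps.

Going by these compounds, it remains open whether the same methoxy, entering at the same place on the core of compound 1, would give a step like the one seen on the core of compound 3. Also open, on these data alone, is how other groups on that aromatic carbon, such as an ethoxy group, a chlorine atom or an amine, would read in this assay on either core.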